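The source may hold more compounds than are shown below. What is called first, only, known or untested is meant among the compounds shown, and "the series" means these compounds.

Three compounds have been measured in a functional assay on DU-145 cells (Homo sapiens) for antiproliferative activity, read by propidium iodide staining, with a stated time of 96 h; on this read-out higher numbers stand for weaker inhibition and lower numbers for stronger inhibition:

Compound 1, `CC(O)(CSc1cccc(C(F)(F)F)c1)C(=O)Nc1ccc(S(F)(F)(F)(F)F)cc1`, gives 26200 nM.
Compound 2, `CC(O)(CSc1cc(C(F)(F)F)cc(C(F)(F)F)c1)C(=O)Nc1ccc(S(F)(F)(F)(F)F)cc1`, gives 29700 nM.
Compound 3, `CC(O)(CSc1cccc(C(F)(F)F)c1)C(=O)Nc1cccc(S(F)(F)(F)(F)F)c1`, gives 19100 nM.

All three share the same overall shape: a short hydroxylated chain that carries an amide on one end and a sulfur-linked aromatic ring on the other, with a pentafluorosulfanyl-bearing aromatic ring attached to the amide nitrogen. Compound 2 differs from compound 1 by trifluoromethyl in place of hydrogen on an aromatic carbon. The step that this change made was a 1.1-fold higher number from compound 1 to compound 2 (0.05 log units; within the scatter), so the two numbers cannot be told apart with confidence. Compound 3 has the same atoms as compound 1 but joined differently; the difference between the two cores is not broken down here. The values of compound 1 and compound 3 lie within the usual scatter of each other, and the same holds for compound 3 against compound 2.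

Compound 4, `CC(O)(CSc1cc(C(F)(F)F)cc(C(F)(F)F)c1)C(=O)Nc1cccc(S(F)(F)(F)(F)F)c1`, has not been measured in this assay. Within the data shown here, it differs from compound 3 by trifluoromethyl in place of hydrogen on an aromatic carbon, and this is the same change, at the same kind of place, as the one from compound 1 to compound 2. The step expected from compound 3 to compound 4 is therefore a 1.1-fold higher number from compound 3 to compound 4 (0.05 log units; within the scatter), set beside the measured step of a 1.1-fold higher number from compound 1 to compound 2 (0.05 log units; within the scatter), because that earlier step a 1.1-fold higher number from compound 1 to compound 2 (0.05 log units; within the scatter) stayed within the scatter. For compound 4 the estimated number is 21500 nM, expected to fall between 12000 nM and 40000 nM.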

Compound 4, half-maximal inhibitory concentration: 9400 nM
The estimate for compound 4 lay 2.3-fold (0.36 log units) above the measured number, and the stated range ends above it.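

Trifluoromethyl in place of hydrogen on an aromatic carbon gives a 2.0-fold lower number from compound 3 to compound 4 (0.31 log units; beyond the scatter) in this assay, so on this core the change can be read, though the step is only modest. Set beside the same change on the core of compound 1, this step still cannot be told apart from the earlier one, even though only one of the two lies beyond the scatter when taken alone: the same change on two cores in this assay, a 1.1-fold higher number (0.05 log units; within the scatter) from compound 1 to compound 2 and a 2.0-fold lower number (0.31 log units; beyond the scatter) from compound 3 to compound 4, 2.3-fold (0.36 log units) apart, within the scatter of two such steps So the two pairs give no firm sign that the core alters what the change does, but with so few pairs they do not prove that it carries over unchanged, and it remains unsettled whether the lower number belongs to the core of compound 3 alone.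

The compounds shown carry only hydrogen or trifluoromethyl at this place, which leaves open how a nitrile, an amine or a carboxylic acid there would compare on either core. From the compounds shown here alone, all four numbers also come from a single read-out in one cell line, so it remains open whether the same steps would appear in other cells.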